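The compounds below may be only part of what the source reports. "The series", "measured", "known", "first", "only" and "open" are said of these compounds alone.

In an ADME assay on L6 cells (Rattus norvegicus) for cytotoxicity, read by resazurin assay, with a stated time of 72 h (a lower number here means a stronger inhibitor, a higher number a weaker inhibitor), three compounds with a shared core give closely matching numbers: compound 1 (`CN(C)C12CC(c3ccccc3)C(CN(C(=O)CN3CCCCC3)C1)C(c1ccccc1)C2`) gives 12100 nM, compound 2 (`CN(C)C12CC(c3ccccc3)C(CN(C(=O)CN3CCCC3)C1)C(c1ccccc1)C2`) gives 12600 nM, and compound 3 (`CN(C)C12CC(c3ccccc3)C(CN(C(=O)CCN3CCCC3)C1)C(c1ccccc1)C2`) gives 11700 nM. Compound 3 therefore stands level with the other two, within the scatter. Compound 4 (`CN(C)C12CC(c3ccccc3)C(CN(CCN3CCCC3)C1)C(c1ccccc1)C2`) differs from compound 3 on an amine nitrogen in a ring: 2-(pyrrolidin-1-yl)ethyl in place of (2-(pyrrolidin-1-yl)ethyl)carbonyl on an amine nitrogen in a ring. Within the data shown here, two measured steps bear on this side chain, a 1.0-fold lower number from compound 1 to compound 3 (0.01 log units; within the scatter) and a 1.1-fold lower number from compound 2 to compound 3 (0.03 log units; within the scatter), and both stay within the scatter. Neither removes the carbonyl, so they offer only weak guidance, and a modest move to a lower number is a cautious expectation. The expected change is a 1.7-fold lower number from compound 3 to compound 4 (0.22 log units; within the scatter). For compound 4, the estimated value is 7000 nM, with an expected range of 2500 nM to 16000 nM.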

Compound 4, half-maximal inhibitory concentration: 5580 nM
Estimate against measurement, compound 4: 1.3-fold (0.10 log units) above, within the range that was stated.
By their numbers in this assay, from the lowest: compound 4; then compounds 3, 1 and 2 (each within the scatter of the next).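

In this assay, among these compounds, losing the carbonyl from the side chain on the amine nitrogen in the ring gives the first change beyond the scatter in this set: a 2.1-fold lower number from compound 3 to compound 4 (0.32 log units; beyond the scatter), alongside a 2.3-fold lower number from compound 2 to compound 4 (0.35 log units; beyond the scatter) and a 2.2-fold lower number from compound 1 to compound 4 (0.34 log units; beyond the scatter). Changing the amine ring or the chain length while keeping the carbonyl had moved nothing beyond the scatter, so only the chain without a carbonyl stands apart here. Nothing measured here accounts for this shift.

Still open, as far as these compounds go, is whether the lower number holds with a longer chain between the ring nitrogen and the pyrrolidine. A piperidine or a dimethylamino group in place of that pyrrolidine is equally untested among these compounds.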